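Compound 3 to compound 4: a shorter chain

A few compounds are considered here, and "the series" means these few. Any claim that something is new, unique, unknown or untested is made for them only; others in the source may bear on it.

Compound 1 `CCCCCN(Cc1ccc(C(=O)NO)cc1)c1ncc(-c2ccc(C)cc2)s1`: 23300 nM
Compound 2 `Cc1ccc(-c2cnc(N(Cc3ccccc3)Cc3ccc(C(=O)NO)cc3)s2)cc1`: 48800 nM
Compound 3 `Cc1ccc(-c2cnc(N(Cc3ccc(C(=O)NO)cc3)CC(C)C)s2)cc1`: 5900 nM

All three values come from a functional assay on HCT-116 cells (Homo sapiens) for antiproliferative activity, read by MTT assay, with a stated time of 48 h (on this read-out lower numbers stand for stronger inhibition of growth and higher numbers for weaker inhibition of growth), and compound 3 stands lowest among them. Compound 4 `CCN(Cc1ccc(C(=O)NO)cc1)c1ncc(-c2ccc(C)cc2)s1` is still unmeasured. The change from compound 3 is methyl in place of isopropyl on a saturated chain carbon bound to a nitrogen on an aromatic ring and reads as methyl in place of isopropyl on a saturated chain carbon bound to a nitrogen on an aromatic ring.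

Three measured steps fall at this same place. The two that end on compound 3 are a 3.9-fold lower number from compound 1 to compound 3 (0.60 log units; beyond the scatter) and an 8.3-fold lower number from compound 2 to compound 3 (0.92 log units; beyond the scatter) and the remaining one is a 2.1-fold higher number from compound 1 to compound 2 (0.32 log units; beyond the scatter) in size. Among the measured compounds shown here, none of the measured compounds carries a chain as short as the one in compound 4, so the direction is uncertain. Compound 3 holds the lowest number, and every other group measured here gives a higher one. A modest rise in this assay is therefore expected, with the estimate being a 2.2-fold higher number from compound 3 to compound 4 (0.34 log units; beyond the scatter) for this change. Compound 4 is expected at 13000 nM within an estimated range from 4500 nM to 35000 nM on this read-out.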

Compound 4, concentration for 50% growth inhibition: 6870 nM
For compound 4 the middle estimate is 1.9-fold (0.28 log units) above the measured one; the range from low to high includes it.
By their numbers in this assay, from the lowest: compounds 3 and 4 (each within the scatter of the next); then compound 1; then compound 2.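

In this assay, cutting isobutyl to ethyl at this position gives a 1.2-fold higher number from compound 3 to compound 4 (0.07 log units; within the scatter), so this shorter, unbranched chain stays level with the branched one. Ethyl also stands clear of the pentyl chain and the phenyl-bearing group, with a 3.4-fold lower number from compound 1 to compound 4 (0.53 log units; beyond the scatter) and a 7.1-fold lower number from compound 2 to compound 4 (0.85 log units; beyond the scatter). Among these four compounds, branching alone therefore does not account for the low number of compound 3, since unbranched chains appear both at that level in compound 4 and higher in compound 1.

No data here explain these steps or show what they reflect in the cells. On these data alone, how far the chain can shrink, and how a methyl group, a cyclopropylmethyl group or a chain ending in an amine would read at this position, remain open.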